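Swapping Bromo for Methoxy Where Every Value Is a Limit

This account rests on a few compounds, and the source may have more. Where it says the series, first, only, none or still open, it means among the compounds named here.

Compound 1 `COc1ccc(/C(Cl)=C/C=C(\C#N)C(=O)c2c(C)[nH]c3ccccc23)cc1`: in a functional assay on MCF7 cells (Homo sapiens) for cytotoxicity, read by sulforhodamine B assay, with a stated time of 48 h (a lower number here means a stronger inhibitor of growth, a higher number a weaker inhibitor of growth), compound 1 gives > 100000 nM, which is a limit of the assay.
Compound 2 `COc1ccc(/C(Cl)=C/C=C(\C#N)C(=O)c2c[nH]c3ccc(Br)cc23)cc1`: in this assay compound 2 gives > 100000 nM, also a limit.
Compound 3 `COc1ccc(/C(Cl)=C/C=C(\C#N)C(=O)c2c[nH]c3ccccc23)cc1OC`: in this assay compound 3 gives > 100000 nM, again a limit.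

Compound 2 therefore stands where the other two stand, at the limit of > 100000 nM in this assay, at which 3 of the 3 values shown sit. Within the data shown here, no two measured compounds differ in one place, so no measured step size is available. Compound 4 `COc1ccc(/C(Cl)=C/C=C(\C#N)C(=O)c2c[nH]c3ccc(OC)cc23)cc1` differs from compound 2 by methoxy in place of bromo on an aromatic carbon, a methoxy in place of bromo on an aromatic carbon. With every measured value a limit, no direction is shown for such a change, and the step from compound 2 to compound 4 is expected to stay within the scatter, a number no higher from compound 2 to compound 4 (the limit leaves the size open). Compound 4 is thus estimated at 100000 nM, with a range from 30000 nM to 300000 nM, and most likely reported as a limit once more.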

Compound 4, concentration for total growth inhibition: > 100000 nM
Compound 4 was reported as a limit; the forecaster's own chance of this, stated with the estimate: 85%; the middle value sits exactly at the limit.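

Compound 2 and compound 4 each give only a limit in this assay, so the step between them cannot be read. The compounds shown leave open how strongly any of them inhibits growth, all sharing one limit: the limit of > 100000 nM in this assay, at which 4 of the 4 values shown sit.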